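A few compounds are considered here, and "the series" means these few. Any claim that something is new, unique, unknown or untested is made for them only; others in the source may bear on it.

Measured in a functional assay on KB cells (Homo sapiens) for inhibition, read by MTT assay, with a stated time of 24 h, tested at 10 ug/mL; a higher number here means more inhibition of growth at the concentration tested, a lower number less inhibition of growth:
Compound 1 `O=C(CCCCC(S)CCS)Nc1ccc(F)cc1`: 13.3%
Compound 2 `O=C(CCCCC(S)CCS)Nc1ccc([N+](=O)[O-])c(C(F)(F)F)c1`: 4.04%

In this assay, compound 2 at 4.04% stands within the usual scatter of compound 1 at 13.3%, so the two cannot be told apart. Compound 3 `O=C(CCCCC(S)CCS)Nc1ccc([N+](=O)[O-])cc1` has hydrogen in place of trifluoromethyl on an aromatic carbon. Among the compounds with values here, no measured pair of compounds differing in one place is available as a guide, so no change beyond the scatter is expected. The expected move is a number 4 percentage points higher from compound 2 to compound 3 (within the scatter). Compound 3 is estimated at 8%, with an expected range from 0% to 20%.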

Compound 3, percent growth inhibition at one concentration: 13.7%
Compound 3: the middle estimate sits 5.7 percentage points below what was measured, and the stated range covers the measured number.
By their numbers in this assay, from the lowest: compounds 2, 1 and 3 (each within the scatter of the next).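

In this assay, hydrogen in place of trifluoromethyl on an aromatic carbon, ortho to a nitro group, gives a number 9.7 percentage points higher from compound 2 to compound 3 (within the scatter), so removing the group from this position produces no change that can be told from the scatter. Nitro in place of fluoro on an aromatic carbon gives a number 0.4 percentage points higher from compound 1 to compound 3 (within the scatter), so that swap cannot be told from the scatter either. No measurement given here explains either step. On these data alone, whether an amine in place of the nitro group, or a longer chain on the carbonyl, would move growth inhibition beyond the scatter remains open.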